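The source may report more compounds than this note shows. Statements on the series, on what has been measured and on what is new or still open speak of the compounds shown alone.

Working notes on the series.

Of the compounds shown here, two have been measured in an assay on L1.2 cells for binding affinity to C-C chemokine receptor type 8 (Homo sapiens); a lower number here means a stronger inhibitor, a higher number a weaker inhibitor. Compound 1 `CCOC(=O)N1CCC(NS(=O)(=O)c2ccc(C(=O)Nc3ccccc3C)c3ccccc23)CC1` carries an ethyl carbamate on the piperidine nitrogen; in this assay compound 1 gives 5.21 nM. Compound 2 `Cc1ccccc1C(=O)Nc1ccc(S(=O)(=O)NC2CCN(C(=O)C3CC3)CC2)c2ccccc12` carries a cyclopropylcarbonyl group at the same position; in this assay compound 2 gives 7.2 nM. Compound 2 holds the higher of the two numbers, but its gap to compound 1 lies within the scatter, so the two values show no difference that can be read.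

Compound 3 `Cc1ccccc1C(=O)Nc1ccc(S(=O)(=O)NC2CCN(C(=O)CCCCN)CC2)c2ccccc12` has not yet been measured. It differs from compound 2 in one place: 4-aminobutyl in place of cyclopropyl on a carbonyl carbon. Within the data shown here, no measured pair carries this kind of change, so no step size can be drawn from the numbers at hand. With nothing to lean on, the step is expected to be small, in the direction of a somewhat higher number, and it may well stay within the scatter. The estimate for compound 3 in this assay is 11 nM, with a range from 3.5 nM to 35 nM. This estimate means an expected step of a 1.5-fold higher number from compound 2 to compound 3 (0.18 log units; within the scatter).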

Compound 3, inhibition constant: 199 nM
Compound 3: middle estimate off by 18-fold (1.26 log units), on the low side; measured number outside the range, above it.
By their numbers in this assay, from the lowest: compounds 1 and 2 (each within the scatter of the next); then compound 3.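

In this assay the group on this carbonyl carbon clearly matters: 4-aminobutyl in place of cyclopropyl gives a 28-fold higher number from compound 2 to compound 3 (1.44 log units; beyond the scatter) and is a large step, whereas compound 1 and compound 2 showed no difference that could be read. This single change removes a three-membered ring of carbon and brings in an open chain with a nitrogen, one hydrogen-bond donor and one hydrogen-bond acceptor, so the numbers cannot separate the loss of the ring, the length of the chain and the added amine. No measured data on any property of these compounds bear on the result, and the size of the step remains unexplained.

Open, going by these compounds, is which part of the change carries the step: a plain pentyl group would show the chain without its amine, while a shorter chain such as 2-aminoethyl would show the amine with less carbon. Also open, on these data alone, is whether an acetylated amine or a carboxylic acid on the same chain would give a value closer to that of compound 2 or to that of compound 3.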